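Trading ethyl for cyclobutyl on a chloro compound

This account rests on a few compounds, and the source may have more. Where it says the series, first, only, none or still open, it means among the compounds named here.

In an ADME assay on Vero cells (Chlorocebus sabaeus) for cytotoxicity, read by CellTiter-Glo, with a stated time of 72 h (a higher number here means that more compound is tolerated, a lower number that less compound is tolerated), compound 1 (`CCNc1n[n+]([O-])c2cc(F)ccc2[n+]1[O-]`) stands at 4.6 ug/mL and compound 2 (`[O-][n+]1nc(NC2CCC2)[n+]([O-])c2ccc(F)cc21`) at 1.6 ug/mL while compound 3 (`CCNc1n[n+]([O-])c2cc(Cl)ccc2[n+]1[O-]`) reads 2.6 ug/mL on the same scale. Compound 3 therefore lies within the usual scatter of both others. Chloro in place of fluoro on an aromatic carbon gave a 1.8-fold lower number from compound 1 to compound 3 (0.25 log units; within the scatter) and so counts for little here. Compound 4 (`[O-][n+]1nc(NC2CCC2)[n+]([O-])c2ccc(Cl)cc21`) differs from compound 3 by cyclobutyl in place of ethyl on a nitrogen on an aromatic ring. The same change gave a 2.9-fold lower number from compound 1 to compound 2 (0.46 log units; beyond the scatter) and bears directly, so a similar modest fall is expected in this assay for this pair. The expected step is a 2.6-fold lower number from compound 3 to compound 4 (0.41 log units; beyond the scatter) in size. Compound 4 is estimated at 1 ug/mL with an expected range of 0.45 ug/mL to 2 ug/mL for this measurement.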

Compound 4, half-maximal cytotoxic concentration: 1.6 ug/mL
Beside the measured number, compound 4's estimate is 1.6-fold (0.20 log units) below it, within the range that was stated.
By their numbers in this assay, from the lowest: compounds 2, 4, 3 and 1 (each within the scatter of the next, the first and the last beyond it).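

In this assay, cyclobutyl in place of ethyl on the chloro compound gives a 1.6-fold lower number from compound 3 to compound 4 (0.21 log units; within the scatter), so on this core the step does not clear the scatter. The two cores still do not truly disagree about this change: the same change on two cores in this assay, a 2.9-fold lower number (0.46 log units; beyond the scatter) from compound 1 to compound 2 and a 1.6-fold lower number (0.21 log units; within the scatter) from compound 3 to compound 4, 1.8-fold (0.25 log units) apart, within the scatter of two such steps. With cyclobutyl on the nitrogen, chloro in place of fluoro gives no change at the digits printed from compound 2 to compound 4 (within the scatter), so this swap again counts for little: the same change on two cores in this assay, a 1.8-fold lower number (0.25 log units; within the scatter) from compound 1 to compound 3 and no change at the digits printed (within the scatter) from compound 2 to compound 4, 1.8-fold (0.25 log units) apart, within the scatter of two such steps.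

The compounds shown do not tell how a chain ending in an amine or a carboxylic acid would read on that nitrogen. Nor do they tell how a methoxy group would read on the aromatic carbon.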